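Swapping Chloro for an Amine Chain: Cytotoxicity Outlook

The source may report more compounds than this note shows. Statements on the series, on what has been measured and on what is new or still open speak of the compounds shown alone.

Measured compounds:
compound 1, `CN(C)CCNc1ccnc2cc(OCc3ccccc3)ccc12`, 1980 nM
compound 2, `Clc1ccnc2cc(OCc3ccccc3)ccc12`, 2470 nM
compound 3, `CCOc1ccc2c(Cl)ccnc2c1`, 3160 nM

Of the compounds shown here, three have been tested in a functional assay on HCT-116 cells (Homo sapiens) for cytotoxicity, read by MTT assay, with a stated time of 48 h; a lower number here means a stronger inhibitor, a higher number a weaker inhibitor. All three values lie within the usual scatter of one another, so none can be called stronger or weaker here. Compound 2 and compound 1 differ in one place: (2-(dimethylamino)ethyl)amino in place of chloro on an aromatic carbon. This change gave a 1.2-fold lower number from compound 2 to compound 1 (0.10 log units; within the scatter). Compound 2 and compound 3 differ in their cores: methyl in place of phenyl on a saturated chain carbon bound to an oxygen on an aromatic ring, which gave a 1.3-fold higher number from compound 2 to compound 3 (0.11 log units; within the scatter).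

Compound 4 `CCOc1ccc2c(NCCN(C)C)ccnc2c1` has not yet been measured. It carries the core of compound 3 with the change already seen between compound 2 and compound 1: (2-(dimethylamino)ethyl)amino in place of chloro on an aromatic carbon. The place is described in the same words for both pairs, so this is the same change, occurring twice among these compounds.

For the measured compounds named here, the one measured instance of this change gave a 1.2-fold lower number from compound 2 to compound 1 (0.10 log units; within the scatter), a step within the scatter. On that basis a step of similar size is expected from compound 3 to compound 4 in this assay, estimated as a 1.2-fold lower number from compound 3 to compound 4 (0.08 log units; within the scatter). Compound 3 gives 3160 nM in this assay. Compound 4 is therefore expected to give about 2600 nM in this assay, estimated to fall between 1300 nM and 5200 nM. Whether the change behaves alike on the core of compound 3 cannot be checked against any further pair here.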

Compound 4, half-maximal inhibitory concentration: 2570 nM
The estimate for compound 4 lay 1.0-fold (0.01 log units) above the measured number, within the range that was stated.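

In this assay, putting (2-(dimethylamino)ethyl)amino in place of chloro on the core of compound 3 gave a 1.2-fold lower number from compound 3 to compound 4 (0.09 log units; within the scatter), and this agrees with the earlier instance of the same change: the same change on two cores in this assay, a 1.2-fold lower number (0.10 log units; within the scatter) from compound 2 to compound 1 and a 1.2-fold lower number (0.09 log units; within the scatter) from compound 3 to compound 4, 1.0-fold (0.01 log units) apart, within the scatter of two such steps The second change, methyl in place of phenyl on a saturated chain carbon bound to an oxygen on an aromatic ring, gave a 1.3-fold higher number from compound 1 to compound 4 (0.11 log units; within the scatter) with the amine chain in place, and it too agrees with its earlier instance: the same change on two cores in this assay, a 1.3-fold higher number (0.11 log units; within the scatter) from compound 2 to compound 3 and a 1.3-fold higher number (0.11 log units; within the scatter) from compound 1 to compound 4, 1.0-fold (0.01 log units) apart, within the scatter of two such steps This shows that, within these four compounds, neither change read differently from one setting to the other, but it does not show that either change has a real effect on the number, as every step lies within the scatter, and two instances of each change say nothing about other cores.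

The compounds shown leave open how a longer chain between the two nitrogens, a cyclic amine such as morpholine, or a carboxylic acid would read in place of chloro. They also leave open what a pyridine ring in place of the phenyl would give, and whether the agreement between steps would hold outside this assay.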